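The source may report more compounds than this note shows. Statements on the series, on what has been measured and on what is new or still open speak of the compounds shown alone.

In a functional assay on HCT-15 cells (Homo sapiens) for cytotoxicity, read by ELISA, with a stated time of 2 days (on this read-out higher numbers stand for weaker inhibition and lower numbers for stronger inhibition), compound 3 (`Oc1cccc(-c2cc(-c3ccccc3)nc(-c3ccccc3)c2)c1`) gives 18000 nM as its half-maximal inhibitory concentration. That number sits within the scatter of compound 1 (`Oc1cccc(-c2cc(-c3ccccc3)cc(-c3cccs3)n2)c1`), which gives 10900 nM in the same test. Compound 2 (`Oc1ccc(-c2cc(-c3ccccc3)cc(-c3ccc(O)cc3)n2)cc1`) gives 3000 nM and stands lower than compound 3 by more than the scatter. Compound 4 (`Oc1cccc(-c2cc(-c3ccccc3)nc(-c3cccs3)c2)c1`) comes from compound 3 by a single change (thiophen-2-yl in place of phenyl on an aromatic carbon): thiophen-2-yl in place of phenyl on an aromatic carbon. Going by the values given here, no measured pair shows this change alone. Compound 1 also carries thiophen-2-yl and at 10900 nM lies within the scatter of compound 3 at 18000 nM so no step beyond the scatter is expected in this assay here. The expected step (a 1.4-fold lower number from compound 3 to compound 4 (0.14 log units; within the scatter)) is therefore small. Compound 4 is estimated at 13000 nM with 5500 nM to 30000 nM as the expected range.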

Compound 4, half-maximal inhibitory concentration: 14100 nM
The estimate for compound 4 lay 1.1-fold (0.04 log units) below the measured number; the range from low to high includes it.
By their numbers in this assay, from the lowest: compound 2; then compounds 1, 4 and 3 (each within the scatter of the next).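

In this assay the step next to the ring nitrogen can now be read directly: thiophen-2-yl in place of phenyl gives a 1.3-fold lower number from compound 3 to compound 4 (0.11 log units; within the scatter) and so stays within the scatter. At this position, meta to a 3-hydroxyphenyl group and meta to a phenyl group, a five-membered aromatic ring with sulfur and a six-membered carbon ring therefore read alike in this test. Nothing available accounts for this result.

On these data alone, whether an amine or a carboxylic acid at this position would move the number beyond the scatter remains open. So does whether the same change at the remaining phenyl group would read alike.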